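Saturated to aromatic ring swap on the side-chain carbon

A few compounds are considered here, and "the series" means these few. Any claim that something is new, unique, unknown or untested is made for them only; others in the source may bear on it.

Measured so far:
Compound 1 `FC(F)(F)c1cc(NCC2CNC2)c2cn[nH]c2c1`: > 100000 nM
Compound 2 `FC(F)(F)c1cc(NC[C@H]2CCCCN2)c2cn[nH]c2c1`: 24000 nM

Compound 1 `FC(F)(F)c1cc(NCC2CNC2)c2cn[nH]c2c1` gives in an assay for inhibition of Indoleamine 2,3-dioxygenase 1 (Homo sapiens), with stated times of 10 min and 60 min (a lower number here means a stronger inhibitor, a higher number a weaker inhibitor), a value that is a limit of the assay and not a number, > 100000 nM; it sits at the limit of > 100000 nM in this assay, at which 1 of the 2 values shown sits. Compound 2 `FC(F)(F)c1cc(NC[C@H]2CCCCN2)c2cn[nH]c2c1` gives in this assay the only actual number shown, 24000 nM. Among the measured compounds shown here, the single measured step, an at least 4.1-fold lower number from compound 1 to compound 2 (0.61 log units; beyond the scatter), moves from a limit to a number, so its size is itself only a lower bound.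

Compound 3 `Nc1cccc(CNc2cc(C(F)(F)F)cc3[nH]ncc23)c1` differs from compound 2 in one place: 3-aminophenyl in place of piperidin-2-yl on a saturated chain carbon bound to a nitrogen on an aromatic ring. For the measured compounds named here, the one measured step exchanges one saturated ring for another saturated ring; none of the measured compounds carries an aromatic group at this place, so no measured step bears directly on the change to compound 3. The expectation therefore rests on compound 2 alone, with wide uncertainty in both directions. Compound 3 is expected at 25000 nM, between 4000 nM and 100000 nM. The estimated step of a 1.0-fold higher number from compound 2 to compound 3 (0.02 log units; within the scatter) is thus expected to stay near the scatter.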

Compound 3, half-maximal inhibitory concentration: > 100000 nM
Compound 3: a limit, no number; the forecaster's own chance of this, stated with the estimate: 30%; middle value at least 4.0-fold (0.60 log units) away from the limit.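

In this assay, compound 3 gives > 100000 nM, a limit of the assay and not a number. Among the compounds shown here, this is the first aromatic group at this place on the saturated chain carbon, and 3-aminophenyl in place of piperidin-2-yl gives an at least 4.1-fold higher number from compound 2 to compound 3 (0.61 log units; beyond the scatter), so the size of this loss is only a lower bound. Among the three groups shown here, piperidin-2-yl alone gives a measurable value, while azetidin-3-yl and 3-aminophenyl both end at the limit, and the step between compound 1 and compound 3 cannot be read, as both values are limits: the limit of > 100000 nM in this assay, at which 2 of the 3 values shown sit.

From the compounds shown here alone, how far compound 3 lies beyond the limit stays open, as does whether the loss belongs to the aromatic ring as such or to the amine carried on it. A plain phenyl or a pyridine ring at this place would separate those two readings, and a longer chain between the nitrogen on the aromatic ring and the piperidine would show whether the value of compound 2, 24000 nM, can be improved on.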